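Swapping the amide substituent in a cytotoxic series

This account rests on a few compounds, and the source may have more. Where it says the series, first, only, none or still open, it means among the compounds named here.

Of the compounds shown here, three with a shared core have been tested in a functional assay on CLL cells (Homo sapiens) for cytotoxicity, read by MTT assay, with a stated time of 48 h; on this read-out lower numbers stand for an effect already at smaller amounts and higher numbers for an effect only at larger amounts of compound. Compound 1 `C=C(CC)C(=O)c1ccc(OCC(=O)Nc2nc3ccccc3s2)c(Cl)c1Cl` gives 1500 nM, the lowest of the two numbers shown. Compound 3 `C=C(CC)C(=O)c1ccc(OCC(=O)Nc2ccc(O)cc2)c(Cl)c1Cl`, which carries a 4-hydroxyphenyl in place of 1,3-benzothiazol-2-yl on an amide-type nitrogen, gives 6400 nM, so the change brings a 4.3-fold higher number from compound 1 to compound 3 (0.63 log units; beyond the scatter). Compound 2 `C=C(CC)C(=O)c1ccc(OCC(=O)NCC(=O)O)c(Cl)c1Cl`, carrying a carboxymethyl at that position, reaches only the limit > 25000 nM; this is the limit of > 25000 nM in this assay, at which 1 of the 3 values shown sits, not a number. That step, an at least 16-fold higher number from compound 1 to compound 2 (1.22 log units; beyond the scatter), shows how much is lost when the aromatic group is removed entirely.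

Compound 4 `C=C(CC)C(=O)c1ccc(OCC(=O)Nc2ccc(O)c(Cl)c2)c(Cl)c1Cl` differs from compound 1 by 3-chloro-4-hydroxyphenyl in place of 1,3-benzothiazol-2-yl on an amide-type nitrogen. Within the data shown here, the closest measured step is the one to compound 3, which kept an aromatic ring bearing a hydroxyl and gave a 4.3-fold higher number from compound 1 to compound 3 (0.63 log units; beyond the scatter). A step of similar size is therefore expected here, upward in this assay: compound 4 is estimated at 5000 nM, within 2000 nM to 13000 nM, meaning a 3.3-fold higher number from compound 1 to compound 4 (0.52 log units; beyond the scatter).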

Compound 4, half-maximal effective concentration: 5500 nM
Compound 4: middle estimate off by 1.1-fold (0.04 log units), on the low side, and the stated range covers the measured number.
By their numbers in this assay, from the lowest: compound 1; then compounds 4 and 3 (each within the scatter of the next). At a limit, above all of these: compound 2.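

In this assay, adding a chloro to the 4-hydroxyphenyl of compound 3 leaves the number unchanged within the scatter (a 1.2-fold lower number from compound 3 to compound 4 (0.07 log units; within the scatter)), so at this amide-type nitrogen the added chloro has no readable effect. It also does not close the gap to the 1,3-benzothiazol-2-yl group (a 3.7-fold higher number from compound 1 to compound 4 (0.56 log units; beyond the scatter)), while the aromatic ring keeps its distance from the carboxymethyl group (an at least 4.5-fold lower number from compound 2 to compound 4 (0.65 log units; beyond the scatter)). For compound 2, that last comparison rests on a limit and not on a number: the limit of > 25000 nM in this assay, at which 1 of the 4 values shown sits.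

The compounds shown leave open what the hydroxyl itself contributes, which a plain phenyl or a 4-aminophenyl at this nitrogen could address. Also open, on these data alone, is whether a chloro would matter on the 1,3-benzothiazol-2-yl group, which gives the lowest number here.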